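A bromo step from compound 1 to compound 4

The compounds below may be only part of what the source reports. "The series", "measured", "known", "first", "only" and "open" are said of these compounds alone.

Measured so far in an ADME assay on HEK-293T cells (Homo sapiens) for cytotoxicity, read by luminescence and CellTiter-Glo, with a stated time of 24 h; a higher number here means that more compound is tolerated, a lower number that less compound is tolerated:
- Compound 1 `CCCNC(=O)C1CCN(C(=O)c2cc3ccsc3n2Cc2ccc(OC)cc2)CC1`: 23400 nM
- Compound 2 `CCCNC(=O)C1CCN(C(=O)c2cc3ncsc3n2Cc2ccc(OC)cc2)CC1`: 42700 nM
- Compound 3 `CCCNC(=O)C1CCN(C(=O)c2cc3sc(-c4ccccc4)cc3n2Cc2ccc(OC)cc2)CC1`: > 100000 nM, a limit and not a number

Compound 1 and compound 2 lie within the usual scatter of each other, so these two numbers do not separate them. The value for compound 3 is a limit of the assay and gives no number to set beside the other two.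

Compound 4 `CCCNC(=O)C1CCN(C(=O)c2cc3cc(Br)sc3n2Cc2ccc(OC)cc2)CC1` has not yet been measured. It differs from compound 1 in one place: bromo in place of hydrogen on an aromatic carbon. Going by the values given here, no measured pair in this set differs in one place only, so no direct step is available as a guide, and no change beyond the scatter is expected in this assay. The expected step is a 1.3-fold higher number from compound 1 to compound 4 (0.11 log units; within the scatter). For compound 4 the estimated value is 30000 nM, with an expected range of 12000 nM to 80000 nM.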

Compound 4, half-maximal cytotoxic concentration: > 100000 nM
Compound 4: a limit, no number (the forecaster's own chance of this, stated with the estimate: 12%); at least 3.3-fold (0.52 log units) between middle value and limit.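

In this assay, going by these compounds alone, bromo in place of hydrogen on an aromatic carbon next to the ring sulfur gives an at least 4.2-fold higher number from compound 1 to compound 4 (0.63 log units; beyond the scatter), the first step in this set between two compounds that differ in one place only. Within the data shown here, this shows that a single heavy atom entering at this position of the five-membered aromatic ring can move the read-out beyond the scatter, which the earlier compounds could not show. The value of compound 4 is a limit and not a number, so the step has a lower bound and no exact size: the limit of > 100000 nM in this assay, at which 2 of the 4 values shown sit.

The compounds shown leave open whether chloro, methyl or an amine at this same position would give a step of similar size. They also leave open whether bromo would have the same effect on the core of compound 2.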